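The compounds below may be only part of what the source reports. "The series", "measured", "known", "first", "only" and "open" are said of these compounds alone.

Going by the values given here, in a functional assay on MGC-803 cells (Homo sapiens) for inhibition, read by MTT assay, with a stated time of 48 h (a lower number here means a stronger inhibitor, a higher number a weaker inhibitor), compound 2 `C/C=C/C(=O)N(Cc1ccc(OC)c(N)c1)c1cc(OC)c(OC)c(OC)c1` gives 150 nM, the lower of the two numbers so far, and compound 1 `C/C=C/C(=O)N(Cc1ccc(OC)c([N+](=O)[O-])c1)c1cc(OC)c(OC)c(OC)c1` gives 590 nM. Next comes compound 3 `C/C=C/C(=O)N(Cc1cccc(O)c1)c1cc(OC)c(OC)c(OC)c1`, with 3-hydroxyphenyl in place of 3-amino-4-methoxyphenyl on a saturated chain carbon bound to an amide-type nitrogen. Among the compounds with values here, the one measured step, a 3.9-fold lower number from compound 1 to compound 2 (0.59 log units; beyond the scatter), is modest and puts amino in place of nitro on an aromatic carbon, so it bears only in part, and no measured compound carries 3-hydroxyphenyl. In this assay a move to a higher number is expected, estimated as a 10-fold higher number from compound 2 to compound 3 (1.00 log units; beyond the scatter). The expected value for compound 3 is 1500 nM, within 300 nM to 8000 nM.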

Compound 3, half-maximal inhibitory concentration: 14100 nM
Beside the measured number, compound 3's estimate is 9.4-fold (0.97 log units) below it; measured number outside the range, above it.
By their numbers in this assay, from the lowest: compound 2; then compound 1; then compound 3.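

In this assay the ring on the saturated chain carbon bound to an amide-type nitrogen proves highly sensitive, with a 94-fold higher number from compound 2 to compound 3 (1.97 log units; beyond the scatter) as 3-hydroxyphenyl replaces 3-amino-4-methoxyphenyl. Both groups carry one hydrogen-bond donor, so keeping that count on the ring does not preserve the number of compound 2 in this pair. Nothing at hand bears on the cause of this loss. The step changes the ring in more than one way, so the shares of the amino and methoxy groups remain unseparated. Also open, going by these compounds, is whether an acetamide or a dimethylamino group on this ring would hold the number of compound 2.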